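The compounds below may be only part of what the source reports. "The series", "measured", "known", "first", "only" and "open" are said of these compounds alone.

In a functional assay on HEL cells (Homo sapiens) (a higher number here means that more compound is tolerated, a lower number that less compound is tolerated), compound 2, `CCCCCCCCCCCc1cc2cn(COCCO)c(O)nc-2n1`, gives a half-maximal cytotoxic concentration of 41000 nM, the lower of the two actual numbers available. Compound 1, `CCCCCCCCCCCc1cc2cn(COCCO)c(=O)nc2o1`, gives 132000 nM, and the gap between the two lies beyond the usual scatter. With a different side chain on the core of compound 1, compound 3, `CCCCC#Cc1cc2cn(COCCO)c(=O)nc2o1`, is reported only as a limit, > 50000 nM.

Compound 4, `CCCCCCc1cc2cn(COCCO)c(O)nc-2n1`, has not yet been measured. It differs from compound 2 by hydrogen in place of pentyl on a saturated chain carbon, six bonds along the chain from an aromatic carbon, with hydrogen in place of pentyl on a saturated chain carbon, six bonds along the chain from an aromatic carbon. Going by the values given here, no measured pair isolates this change, so the expectation is tentative. Among the compounds with values here, it leans on compound 3, the only compound without the long chain, whose > 50000 nM is a limit. An upward step a 2.2-fold higher number from compound 2 to compound 4 (0.34 log units; beyond the scatter) is expected in this assay, meaning that more compound would be tolerated, and it is expected to lie beyond the scatter. Compound 4 is estimated at 90000 nM, with an expected range of 35000 nM to 230000 nM.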

Compound 4, half-maximal cytotoxic concentration: > 200000 nM
Compound 4 was reported as a limit; the forecaster's own chance of this, stated with the estimate: 45%; middle value at least 2.2-fold (0.34 log units) away from the limit.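

Removing the pentyl from the chain of compound 2, leaving hydrogen on a saturated chain carbon, six bonds along the chain from an aromatic carbon, gives in this assay an at least 4.8-fold higher number from compound 2 to compound 4 (0.68 log units; beyond the scatter). Going by these compounds alone, this is the first comparison here that isolates chain length on a single core, and it shows that the shorter chain of compound 4 is tolerated at higher concentrations. From the compounds shown here alone, compound 4 stands at > 200000 nM, which is a limit, so the step fixes only a minimum size and the full size stays unknown.

Going by these compounds, whether the number rises gradually or abruptly with an intermediate chain such as octyl remains open. So does whether the same shortening would have a comparable effect on the core of compound 1, or how an amine on the chain would compare.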